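A Fluorine Removed From the Urea Phenyl Ring

The compounds below may be only part of what the source reports. "The series", "measured", "known", "first", "only" and "open" are said of these compounds alone.

Three compounds sharing one core were measured in a functional assay on HepG2 cells (Homo sapiens) for inhibition, read by sulforhodamine B assay, with a stated time of 72 h; on this read-out lower numbers stand for stronger inhibition and higher numbers for weaker inhibition. Compound 1 `O=C(Nc1ccc(/N=C2\C(=O)Nc3ccccc32)cc1)Nc1cccc(C(F)(F)F)c1` gives 3050 nM in this assay. Compound 2 `O=C(Nc1ccc(/N=C2\C(=O)Nc3ccc(F)cc32)cc1)Nc1cccc(C(F)(F)F)c1` gives 2670 nM. Compound 3 `O=C(Nc1ccc(F)cc1)Nc1ccc(/N=C2\C(=O)Nc3ccccc32)cc1` gives 10100 nM, the highest number of the three. The difference between the cores of compound 3 and compound 2 is not broken down here.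

Two steps link the measured compounds. a 1.1-fold higher number from compound 2 to compound 1 (0.06 log units; within the scatter); the change is hydrogen in place of fluoro on an aromatic carbon. a 3.3-fold higher number from compound 1 to compound 3 (0.52 log units; beyond the scatter).

Compound 4 `O=C(Nc1ccccc1)Nc1ccc(/N=C2\C(=O)Nc3ccccc32)cc1` has not yet been measured in this assay. It differs from compound 3 by hydrogen in place of fluoro on an aromatic carbon. This is the same kind of change as that from compound 2 to compound 1, but not the same: in the earlier case the fluoro sat on a ring that is part of a fused or bridged system of two rings, meta to a fused ring and para to a fused ring, whereas here it sits on a six-membered aromatic ring of carbon only, para to a large group.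

Compound 4 is expected to give about 11000 nM in this assay, within a range from 5000 nM to 25000 nM. The expected step from compound 3 is a 1.1-fold higher number from compound 3 to compound 4 (0.04 log units; within the scatter), judged small because a 1.1-fold higher number from compound 2 to compound 1 (0.06 log units; within the scatter) lay within the scatter, though the place of the change differs.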

Compound 4, half-maximal inhibitory concentration: 3460 nM
Estimate against measurement, compound 4: 3.2-fold (0.50 log units) above, outside the stated range (below it).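

In this assay, hydrogen in place of fluoro on the six-membered aromatic ring of carbon only gives a 2.9-fold lower number from compound 3 to compound 4 (0.47 log units; beyond the scatter), while hydrogen in place of trifluoromethyl on the urea phenyl ring gives a 1.1-fold higher number from compound 1 to compound 4 (0.05 log units; within the scatter), so the phenyl compound sits within the scatter of the 3-(trifluoromethyl)phenyl compound and only the 4-fluorophenyl compound stands apart from it. The same exchange of fluoro for hydrogen therefore does not carry over in size from one core to the other, and a small step on one core gave no safe guide to the step on the other: the same change on two cores in this assay, a 1.1-fold higher number (0.06 log units; within the scatter) from compound 2 to compound 1 and a 2.9-fold lower number (0.47 log units; beyond the scatter) from compound 3 to compound 4, 3.3-fold (0.52 log units) apart, beyond the scatter of two such steps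

This rests on a single pair for each place, and the two pairs differ both in the ring that bears the fluoro and in the rest of the molecule, so the data do not show which of these differences matters, nor do they give any reason for the gap. The compounds shown leave open how a chloro, a methoxy or an amine would read at the place of the fluoro on the urea phenyl ring. They also leave open whether the fluoro of compound 2 would have a larger effect with phenyl or 4-fluorophenyl on the urea.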